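The source may report more compounds than this note shows. Statements on the series, on what has been measured and on what is new or still open speak of the compounds shown alone.

Of the compounds shown here, three have been measured in a functional assay on PC-3 cells (Homo sapiens) for cytotoxicity, read by sulforhodamine B assay, tested at 10 uM; on this read-out higher numbers stand for more inhibition at the one concentration tested (going by the name of the read-out) and lower numbers for less inhibition. Compound 1 `CC(=O)OC[C@H]1O[C@@H](n2cc(-c3cn(Cc4ccccc4)nn3)c(=O)[nH]c2=O)C[C@@H]1OC(C)=O` gives 92.1%, and compound 3 `CC(=O)OC[C@H]1O[C@@H](n2cc(-c3cn(Cc4ccc(C(C)(C)C)cc4)nn3)c(=O)[nH]c2=O)C[C@@H]1OC(C)=O` gives 90.4%; the step of a number 1.7 percentage points lower from compound 1 to compound 3 (within the scatter) shows that adding a tert-butyl group to the benzene ring left the read-out unchanged within the usual scatter. Compound 2 `CCCCc1ccc(-c2cc(-c3cn([C@H]4C[C@H](OC(C)=O)[C@@H](COC(C)=O)O4)c(=O)[nH]c3=O)on2)cc1` stands apart from these two: in this assay compound 2 gives 30.4%, the lowest of the three numbers, lying beyond the scatter below both compound 1 and compound 3.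

Compound 4 `CC(=O)OC[C@H]1O[C@@H](n2cc(-c3cc(C)no3)c(=O)[nH]c2=O)C[C@@H]1OC(C)=O` is reached from compound 2 by a single structural change: methyl in place of 4-butylphenyl on an aromatic carbon. Among the compounds with values here, no measured step bears directly on this change. Within the data shown here, the only step available, a number 1.7 percentage points lower from compound 1 to compound 3 (within the scatter), concerns a different group on a different ring and was flat, so it offers no guide to how removing a 4-butylphenyl group and leaving a methyl in its place will move the number. The core shared by compound 1 and compound 3 gave high inhibition, while compound 2, with its different five-membered ring and its large group, gave low inhibition; which of those two features is responsible cannot be separated from the data.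

With this uncertainty, compound 4 is expected to give 45%, within a range from 15% to 80%. That estimate corresponds to an expected step of a number 14.6 percentage points higher from compound 2 to compound 4 (beyond the scatter).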

Compound 4, a percentage reported as inhibition, at one concentration (the size of the read-out at that concentration, not a potency): 92.4%
Beside the measured number, compound 4's estimate is 47.4 percentage points below it; the measured number lies above the stated range.
By their numbers in this assay, from the lowest: compound 2; then compounds 3, 1 and 4 (each within the scatter of the next).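

Replacing the 4-butylphenyl group with methyl on this aromatic carbon, next to the ring nitrogen, produces a large change in this assay: a number 62 percentage points higher from compound 2 to compound 4 (beyond the scatter). Compound 2 and compound 4 share the same five-membered aromatic ring with one nitrogen and one oxygen and differ only at this position, so this ring does not by itself go with low inhibition, and the low reading of compound 2 is tied to the 4-butylphenyl group on this carbon. No measurement at hand speaks to the reason for this link between the group and the read-out.

The compounds shown leave open which part of the 4-butylphenyl group goes with the low reading, the butyl chain or the benzene ring, and a plain phenyl group at this position would begin to separate the two. They also leave open how far the group on this carbon can grow beyond methyl before inhibition falls, a question that an ethyl group, a longer chain or a benzyl group could address.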